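Cyclobutyl for isopropyl on the carbamate nitrogen

This account rests on a few compounds, and the source may have more. Where it says the series, first, only, none or still open, it means among the compounds named here.

Three compounds share one core and differ at the group on the primary oxygen. Compound 1 `CC/N=C(\S)OC[C@H]1OC(n2cnc3c(NC4CCOC4)ncnc32)[C@H](O)[C@@H]1O` gives 33 nM in an assay on DDT1 cells (Cricetulus griseus) for binding affinity to adenosine receptor A1 (Homo sapiens), read by radioligand binding; on this read-out higher numbers stand for weaker inhibition and lower numbers for stronger inhibition. Compound 2 `CCC/N=C(\S)OC[C@H]1OC(n2cnc3c(NC4CCOC4)ncnc32)[C@H](O)[C@@H]1O` gives 50 nM, and the change is a 1.5-fold higher number from compound 1 to compound 2 (0.18 log units; within the scatter). Compound 3 `CC(C)NC(=O)OC[C@H]1OC(n2cnc3c(NC4CCOC4)ncnc32)[C@H](O)[C@@H]1O` gives 78 nM, the highest of the three numbers; its step from compound 2 is a 1.6-fold higher number from compound 2 to compound 3 (0.19 log units; within the scatter), and from compound 1 it is a 2.4-fold higher number from compound 1 to compound 3 (0.37 log units; beyond the scatter).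

Compound 4 `O=C(NC1CCC1)OC[C@H]1OC(n2cnc3c(NC4CCOC4)ncnc32)[C@H](O)[C@@H]1O` differs from compound 3 by cyclobutyl in place of isopropyl on an amide-type nitrogen. Among the compounds with values here, no measured step touches this nitrogen; the nearest comparison is the small chain growth from compound 1 to compound 2, which stayed within the scatter, while the larger swap of the whole group gave only a modest step. An alkyl change of this size is therefore expected to move the number little, and no step beyond the scatter is expected. Compound 4 is estimated at 70 nM, between 30 nM and 180 nM, which means an expected step of a 1.1-fold lower number from compound 3 to compound 4 (0.05 log units; within the scatter).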

Compound 4, inhibition constant: 306 nM
Compound 4: the middle estimate sits 4.4-fold (0.64 log units) below what was measured; the measured number lies above the stated range.
By their numbers in this assay, from the lowest: compounds 1, 2 and 3 (each within the scatter of the next, the first and the last beyond it); then compound 4.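

The amide-type nitrogen proved sensitive to the alkyl group it carries: in this assay, cyclobutyl in place of isopropyl gives a 3.9-fold higher number from compound 3 to compound 4 (0.59 log units; beyond the scatter), the largest step yet for a change this small. Compared with the sulfur-bearing groups on the oxygen, the cyclobutylcarbamoyl group lies further out still, with a 6.1-fold higher number from compound 2 to compound 4 (0.79 log units; beyond the scatter) and a 9.3-fold higher number from compound 1 to compound 4 (0.97 log units; beyond the scatter). Nothing available explains this loss.

Going by these compounds, with a single ring on this nitrogen, the effect of the ring cannot be separated from that of the added carbon, so it remains open whether cyclopropyl, cyclopentyl or an open n-butyl chain would track compound 3 or compound 4. On these data alone, it is also open whether the same swap would have a similar effect on the sulfur-bearing group of compound 1.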